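The source may report more compounds than this note shows. Statements on the series, on what has been measured and on what is new or still open speak of the compounds shown alone.

Measured so far in a functional assay on MCF7 cells (Homo sapiens) for antiproliferative activity (on this read-out higher numbers stand for weaker inhibition and lower numbers for stronger inhibition), with limits only
compound 1 `O=C(CCl)Nc1ccc(-c2nc3ccccc3s2)cc1` gives > 10 nM as a limit
compound 2 `O=C(CCl)Nc1ccc(-c2nc3ccccc3o2)cc1` gives > 1000 nM as a limit
compound 3 `O=C(CCl)Nc1ccc(-c2nc3ccccc3s2)cc1I` gives > 10 nM as a limit

No measured value in this set is an exact number. The series shows the limit of > 10 nM in this assay, at which 2 of the 3 values shown sit, and also the limit of > 1000 nM in this assay, at which 1 of the 3 values shown sits, as its only read-outs. Compound 1 therefore has no exact place on the scale, and its > 10 nM is a limit.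

Compound 4 `C/C(S)=N/c1ccc(-c2nc3ccccc3s2)cc1` keeps the core of compound 1 and carries the change a group of 4 heavy atoms (2 carbon, 1 nitrogen, 1 sulfur; no ring) in place of a group of 5 heavy atoms (2 carbon, 1 nitrogen, 1 oxygen, 1 chlorine; no ring), on an aromatic carbon in a single place. Within the data shown here, the one measured step in a single place, a step that the two limits leave unreadable from compound 1 to compound 3 with iodo in place of hydrogen on an aromatic carbon, gives no size and does not involve the group that leaves. Among the measured compounds shown here, no measured step thus sets a size or a direction for this change in this assay and only a wide expectation is possible.

The estimated step that the limit leaves unreadable from compound 1 to compound 4 is a loose expectation with its direction open. For compound 4 the estimate is 300 nM with an expected range of 10 nM to 10000 nM in this read-out, and a report as a limit would not surprise.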

Compound 4, half-maximal inhibitory concentration: > 100 nM
Compound 4 gave a limit, no number; the forecaster's own chance of this, stated with the estimate: 60%; the middle value lies beyond the limit too.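

Compound 4 gives > 100 nM, a limit and not a number. Compound 1 also stands only as a limit, and the step between compound 1 and compound 4 cannot be read. The compounds shown leave open where any of them sits on the scale in this assay, and whether replacing the ((chloromethyl)carbonyl)amino group shifts the read-out at all.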